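Lengthening the chain to the 4-chlorophenoxy end

The compounds below may be only part of what the source reports. "The series", "measured", "known", "first", "only" and "open" are said of these compounds alone.

Compound 1 `CC1C(=O)N(CCCCCCOc2ccc(Cl)cc2)/C(=N\C#N)N1c1ccncc1` and compound 2 `CC1C(=O)N(CCCCCCCOc2ccc(Cl)cc2)/C(=N\C#N)N1c1ccncc1` share one core and differ only in the chain that carries the 4-chlorophenoxy group. In a functional assay on HONE1 cells for cytotoxicity against HONE1 cell line (Homo sapiens) (on this read-out higher numbers stand for weaker inhibition and lower numbers for stronger inhibition), compound 1 gives 303 nM, and compound 2 gives 371 nM. The change between them is (4-chlorophenoxy)methyl in place of 4-chlorophenoxy on a saturated chain carbon, six bonds along the chain from an amide-type nitrogen in a ring, and it produced a 1.2-fold higher number from compound 1 to compound 2 (0.09 log units; within the scatter).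

Compound 3 `N#C/N=C1\N(CCCCCOc2ccc(Cl)cc2)C(=O)C(c2ccccc2)N1c1ccncc1` carries a different core; how the core of compound 3 differs from the core of compound 1 is not broken down here. In this assay compound 3 gives 373 nM, a number that sits within the scatter of compound 2 and of compound 1.

Compound 4 `N#C/N=C1\N(CCCCCCOc2ccc(Cl)cc2)C(=O)C(c2ccccc2)N1c1ccncc1` is not yet measured. It differs from compound 3 by (4-chlorophenoxy)methyl in place of 4-chlorophenoxy on a saturated chain carbon, five bonds along the chain from an amide-type nitrogen in a ring. For the measured compounds named here, this is the same kind of change as the one from compound 1 to compound 2, but not the same change: in the measured pair the saturated chain carbon lies six bonds along the chain from the amide-type nitrogen in the ring, whereas in compound 3 it lies five bonds along the chain from that nitrogen.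

The expectation for compound 4 in this assay rests on one precedent. Because a 1.2-fold higher number from compound 1 to compound 2 (0.09 log units; within the scatter) stayed within the scatter, a step of similar size is expected here, namely a 1.1-fold higher number from compound 3 to compound 4 (0.05 log units; within the scatter). The estimate for compound 4 in this assay is 420 nM, with a range from 200 nM to 900 nM. Going by the values given here, the range is kept wide; no measured step shows that the chain change behaves alike on the core of compound 3.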

Compound 4, half-maximal inhibitory concentration: 337 nM
Estimate against measurement, compound 4: 1.2-fold (0.10 log units) above, within the range that was stated.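

Set beside the earlier step, the change from 4-chlorophenoxy to (4-chlorophenoxy)methyl shows no difference between the two cores in this assay: the same change on two cores in this assay, a 1.2-fold higher number (0.09 log units; within the scatter) from compound 1 to compound 2 and a 1.1-fold lower number (0.04 log units; within the scatter) from compound 3 to compound 4, 1.4-fold (0.13 log units) apart, within the scatter of two such steps. On the core of compound 3 the change gives a 1.1-fold lower number from compound 3 to compound 4 (0.04 log units; within the scatter), and phenyl in place of methyl on a saturated ring carbon, with the chain held the same, gives a 1.1-fold higher number from compound 1 to compound 4 (0.05 log units; within the scatter), so neither step leaves the scatter. This shows that the chain change carried over here without a visible shift, but both steps are small, so the agreement does not show that a change with a large effect on one core would carry over to the other, and a single pair of steps sets no rule for the series.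

The compounds shown leave open whether a longer chain than that of compound 2 would stay within the scatter on either core, and whether a much shorter chain would do so. They also leave open what an amine or a carboxylic acid in place of the 4-chlorophenoxy end would do, and what hydrogen or benzyl would do in place of methyl or phenyl on the saturated ring carbon.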